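The source may report more compounds than this note shows. Statements on the series, on what has been measured and on what is new or still open speak of the compounds shown alone.

Measured so far, with the compound still open:
- compound 1 `N#CC1(c2cc(CCO)cc(-c3ccnc4[nH]nc(C(F)(F)F)c34)c2)CC1` gives 17% in an ADME assay on S9 fraction from liver (Rattus norvegicus) for metabolic stability, read by LC-MS, using NADPH, with a stated time of 60 min, tested at 10 uM; on this read-out lower numbers stand for a less stable compound and higher numbers for a more stable compound
- compound 2 `N#CC1(c2cc(CC(O)C3CC3)cc(-c3ccnc4[nH]nc(C(F)(F)F)c34)c2)CC1` gives 0% in this assay
- compound 3 `COCC(O)Cc1cc(-c2ccnc3[nH]nc(C(F)(F)F)c23)cc(C2(C#N)CC2)c1` has not been measured

Compound 2, at 0%, holds the lower of the two numbers, and compound 1 stands higher, beyond the scatter. The change to compound 3 is methoxymethyl in place of cyclopropyl on a saturated chain carbon bound to an oxygen on a saturated carbon and a saturated chain carbon. For the measured compounds named here, one measured step bears on this place, where cyclopropyl entered in place of hydrogen: a number 17 percentage points lower from compound 1 to compound 2 (beyond the scatter). Going by the values given here, no measured compound carries methoxymethyl, so the evidence is thin. Going by that single step, losing the cyclopropyl is expected to bring a modest rise in this assay, of similar size or less. The estimate for this is a number 12 percentage points higher from compound 2 to compound 3 (beyond the scatter) as the expected step. For compound 3 the estimated value is 12%, with an expected range from 0% to 30% in this read-out.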

Compound 3, percent of the compound remaining: 51%
Estimate against measurement, compound 3: 39 percentage points below, and the stated range ends below it.
By their numbers in this assay, from the lowest: compound 2; then compound 1; then compound 3.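

In this assay, methoxymethyl in place of hydrogen gives a number 34 percentage points higher from compound 1 to compound 3 (beyond the scatter), the opposite direction to the step seen with cyclopropyl, so a group added at this saturated chain carbon can move the number either way. Exchanging one group of 3 heavy atoms for another gives a number 51 percentage points higher from compound 2 to compound 3 (beyond the scatter), which shows that the identity of the group, and not its heavy-atom count, separates these compounds. Nothing available explains why the two groups part so widely.

The change to compound 3 removes a ring and adds an oxygen together, so the compounds shown do not separate these two parts. Going by these compounds, whether an open ethyl chain without oxygen, an ethoxymethyl group or an aminomethyl group would behave like methoxymethyl remains open.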